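Chloro for Fluoro on Two Related Cores

A few compounds are considered here, and "the series" means these few. Any claim that something is new, unique, unknown or untested is made for them only; others in the source may bear on it.

Measured compounds and their values:
compound 1, `Fc1ccc(-c2noc3c2CCNCC3)cc1`: > 10000 nM
compound 2, `Fc1ccc(-c2n[nH]c3c2CCNCC3)cc1`: > 10000 nM
compound 3, `Clc1ccc(-c2noc3c2CCNCC3)cc1`: > 10000 nM

In an assay on cells for displacement of a labelled ligand from 5-hydroxytryptamine receptor 1B (Homo sapiens), read by scintillation counting, with a stated time of 1.5 h (on this read-out higher numbers stand for weaker inhibition and lower numbers for stronger inhibition), compound 1 gives > 10000 nM, which is a limit of the assay and not a number. In this assay compound 3 gives > 10000 nM, again a limit and not a number. Compound 3 differs from compound 1 by chloro in place of fluoro on an aromatic carbon, and the step that the two limits leave unreadable from compound 1 to compound 3 cannot be sized from two limits. Compound 2 has a different core; how the two cores differ is not broken down here. In this assay compound 2 gives > 10000 nM, also a limit and not a number.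

Compound 4, `Clc1ccc(-c2n[nH]c3c2CCNCC3)cc1`, is not yet measured. It differs from compound 2 by chloro in place of fluoro on an aromatic carbon, the same change as that from compound 1 to compound 3. For the measured compounds named here, the expected step that the limit leaves unreadable from compound 2 to compound 4 rests on (the limit of > 10000 nM in this assay, at which 3 of the 3 values shown sit), since every value so far sits at that limit. Compound 4 is therefore estimated at 15000 nM in this assay, with an expected range from 5000 nM to 50000 nM.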

Compound 4, inhibition constant: > 10000 nM
Compound 4: only a limit was reported; the forecaster's own chance of this, stated with the estimate: 80%; the middle value is on the limit's open side.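

No step can be read from compound 2 to compound 4, since each gives only a limit of the assay and not a number: the limit of > 10000 nM in this assay, at which 4 of the 4 values shown sit. The compounds shown leave open how strong the inhibition of any of them is, and whether chloro in place of fluoro changes it on either core.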